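Removing a Chloro Group: What Earlier Data Suggest

The compounds below may be only part of what the source reports. "The series", "measured", "known", "first", "only" and "open" are said of these compounds alone.

Three compounds have been measured in an in vitro functional assay on HEK293-A cells for positive allosteric modulation of metabotropic glutamate receptor 5 (Homo sapiens), read by FLIPR and calcium flux; a lower number here means that less compound is needed, a higher number that more compound is needed for the effect:
compound 1, `O=C1CC(c2nc(-c3ccc(F)cc3)no2)CN1c1ccc(Cl)cc1`, gives 1700 nM;
compound 2, `O=C1CC(c2nc(-c3ccc(F)cc3)no2)CN1c1ccc(Cl)c(Cl)c1`, gives 2300 nM;
compound 3, `Cc1ccc(N2CC(c3nc(-c4cccc(Cl)c4)no3)CC2=O)cc1`, gives 630 nM.

Compound 3 has the lowest number of the three, and its distance from compound 1 and from compound 2 is beyond the scatter. Compound 1 and compound 2 differ in one place only, (hydrogen in place of chloro on an aromatic carbon), and this step gave a 1.4-fold lower number from compound 2 to compound 1 (0.13 log units; within the scatter). How the core of compound 3 differs from the core of compound 2 is not broken down here.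

Compound 4, `Cc1ccc(N2CC(c3nc(-c4ccccc4)no3)CC2=O)cc1`, has not yet been measured. It differs from compound 3 by hydrogen in place of chloro on an aromatic carbon. This is the same kind of change as that from compound 2 to compound 1, though not the same: in compound 2 the departing chloro sits ortho to a chloro group, whereas in compound 3 it does not.

Because the step of a 1.4-fold lower number from compound 2 to compound 1 (0.13 log units; within the scatter) stayed within the scatter, a similarly small step is expected here, estimated as a 1.3-fold higher number from compound 3 to compound 4 (0.10 log units; within the scatter) in this assay. Compound 4 is therefore expected to give about 800 nM, with a likely range from 350 nM to 1900 nM.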

Compound 4, half-maximal effective concentration: 384 nM
Compound 4: the middle estimate sits 2.1-fold (0.32 log units) above what was measured; measured number inside the range.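

In this assay, putting hydrogen in place of the chloro of the 3-chlorophenyl group gave a 1.6-fold lower number from compound 3 to compound 4 (0.22 log units; within the scatter), so on this core the chloro can go without a change that stands clear of the scatter. The same change gave matching results on the two cores, and nothing separates the two steps: the same change on two cores in this assay, a 1.4-fold lower number (0.13 log units; within the scatter) from compound 2 to compound 1 and a 1.6-fold lower number (0.22 log units; within the scatter) from compound 3 to compound 4, 1.2-fold (0.08 log units) apart, within the scatter of two such steps This shows that, for these two pairs, the step carried over from one core to the other as a small one, but two pairs cannot show that it would stay small on every core in the series, and they say nothing about why it is small.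

On these data alone, the pairs compare only chloro with hydrogen, so what a methoxy group, a nitrile, an amine or a carboxylic acid would do in that place remains open. Also open, as far as these compounds go, is whether any such group would give a step that stands beyond the scatter on either core.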